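From a Methylcarbamoyl Arm to a Sulfur-Bearing One

The compounds below may be only part of what the source reports. "The series", "measured", "known", "first", "only" and "open" are said of these compounds alone.

Of the compounds shown here, three built on one shared core have been tested in a functional assay on the whole organism (stomach) for inhibition, with Rattus norvegicus as the target, at a dose of 100 mg/kg by the intraduodenal route; on this read-out higher numbers stand for more inhibition at the one dose given (going by the name of the read-out) and lower numbers for less inhibition. Compound 1 `O=c1cccnn1CCC(=S)N1CCCC1` gives 29.7%. Compound 2 `CNC(=O)CCn1nc(-c2ccccc2)ccc1=O` gives 3.5%, the lowest of the three numbers. Compound 3 `C/N=C(/S)CCCCCn1nc(-c2ccccc2)ccc1=O` gives 92.3%. For the measured compounds named here, the only counted step between these compounds runs a number 88.8 percentage points higher from compound 2 to compound 3 (beyond the scatter). Compound 4 `N=C(S)Cn1nc(-c2ccccc2)ccc1=O` has not yet been tested. It differs from compound 2 in one place: a group of 3 heavy atoms (1 carbon, 1 nitrogen, 1 sulfur; no ring) in place of a group of 5 heavy atoms (3 carbon, 1 nitrogen, 1 oxygen; no ring), on a saturated chain carbon bound to an aromatic nitrogen. Going by the values given here, the one measured step bears on this change in that it also trades an oxygen-bearing group for a sulfur-bearing one on the chain, though there the entering group is also much larger, whereas here it is smaller than the group it replaces. The rise seen from compound 2 to compound 3 points upward, but its full size may not carry over, and compound 1, which also carries a sulfur-bearing group on a short chain, sits well below compound 3. For compound 4 a step of a number 36.5 percentage points higher from compound 2 to compound 4 (beyond the scatter) is therefore expected, giving an estimate of 40% in this assay, with a range from 10% to 80%.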

Compound 4, a percentage reported as inhibition, in the whole organism at one dose (the size of the read-out at that dose, not a potency): 5.5%
Beside the measured number, compound 4's estimate is 34.5 percentage points above it, and the stated range ends above it.
By their numbers in this assay, from the lowest: compounds 2 and 4 (each within the scatter of the next); then compound 1; then compound 3.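

In this assay, putting the new sulfur-bearing group in place of the (methylcarbamoyl)methyl group, on a saturated chain carbon bound to an aromatic nitrogen, gives a number 2 percentage points higher from compound 2 to compound 4 (within the scatter). Sulfur in this short group therefore does not bring the large rise seen as a number 88.8 percentage points higher from compound 2 to compound 3 (beyond the scatter), a step in which the entering group has more heavy atoms than the one it replaces. Nothing measured here explains why the two steps differ in size.

The compounds shown leave open whether the rise in compound 3 follows its longer chain, its sulfur-bearing end or the two together. A longer chain ending in methylcarbamoyl, set against the same chain ending in a carboxylic acid or an amine, would help separate chain length from the end group.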